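Swapping the aryl group on the enone chain of compound 1

The compounds below may be only part of what the source reports. "The series", "measured", "known", "first", "only" and "open" are said of these compounds alone.

Compound 1: `COc1ccc(/C=C/C(=O)c2ccc(OC)c3c2OC(C)(C)C=C3)c(F)c1`, 4880 nM
Compound 2: `COc1ccc(C(=O)/C=C/c2ccccc2Cl)c2c1C=CC(C)(C)O2`, > 10000 nM

The series shares one core and varies the aromatic group on the enone chain. For the measured compounds named here, in a functional assay on SK-OV-3 cells (Homo sapiens) for antiproliferative activity, read by MTT assay, with a stated time of 24 h (on this read-out lower numbers stand for stronger inhibition and higher numbers for weaker inhibition), compound 1 gives 4880 nM, the only actual number among the two measured compounds. Compound 2 reaches only the limit of the assay, > 10000 nM; this is a limit of the assay, not a number (the limit of > 10000 nM in this assay, at which 1 of the 2 values shown sits). Going by the values given here, the one measured step, an at least 2.0-fold higher number from compound 1 to compound 2 (0.31 log units; beyond the scatter), shows that replacing the 2-fluoro-4-methoxyphenyl with a 2-chlorophenyl weakens inhibition by at least a modest amount.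

The unmeasured compound 3, `COc1ccccc1/C=C/C(=O)c1ccc(OC)c2c1OC(C)(C)C=C2`, differs from compound 1 as follows: 2-methoxyphenyl in place of 2-fluoro-4-methoxyphenyl on a double-bonded chain carbon bound to a double-bonded chain carbon. This change resembles the step from compound 1 to compound 2 in removing the fluorine, yet keeps a methoxy group on the ring, so only part of that step is expected to carry over. A small to modest weakening is therefore expected, a 1.5-fold higher number from compound 1 to compound 3 (0.19 log units; within the scatter), with a real chance that the assay again reports only a limit. The estimate for compound 3 in this assay is 7500 nM, with a range from 3500 nM to 16000 nM.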

Compound 3, half-maximal inhibitory concentration: > 10000 nM
Compound 3 ended at the assay's limit; the forecaster's own chance of this, stated with the estimate: 30%; middle value at least 1.3-fold (0.12 log units) away from the limit.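

In this assay, the step of an at least 2.0-fold higher number from compound 1 to compound 3 (0.31 log units; beyond the scatter) shows that a second replacement of the 2-fluoro-4-methoxyphenyl group on this double-bonded chain carbon also weakens inhibition beyond the scatter, so the loss is not confined to the 2-chlorophenyl group of compound 2. The 2-methoxyphenyl group still carries a methoxy, so a methoxy on this ring is not enough by itself to keep the activity of compound 1, and compound 3 gives only a limit of the assay, > 10000 nM. The step between compound 2 and compound 3 cannot be read, which leaves the 2-methoxyphenyl and 2-chlorophenyl groups unranked: the limit of > 10000 nM in this assay, at which 2 of the 3 values shown sit.

The compounds shown leave open whether the fluoro or the methoxy of the 2-fluoro-4-methoxyphenyl group matters more, as neither a 2-fluorophenyl nor a 4-methoxyphenyl group stands among them to separate the two. Also open, on these data alone, is how a ring bearing an amine or a carboxylic acid in this place would read in this assay.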